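The source may report more compounds than this note shows. Statements on the series, on what has been measured and on what is new or still open speak of the compounds shown alone.

Measured compounds:
compound 1, `CNc1nccc(N2CC[C@H](NC(=O)Nc3cccc(C#N)c3)C2)n1` — 3480 nM
compound 2, `O=C(Nc1ccc(Cl)c(C(F)(F)F)c1)N[C@H]1CCN(c2ccnc(NC3CC3)n2)C1` — 20.3 nM

In an assay on a protein complex for displacement of a labelled ligand from CDK8/Cyclin C (Homo sapiens), read by TR-FRET, with a stated time of 1 h (a higher number here means a weaker inhibitor, a lower number a stronger inhibitor), compound 1 gives 3480 nM, the highest of the two numbers seen so far. Going by the values given here, its nearest neighbour, compound 2, gives 20.3 nM, a gap that lies well beyond the scatter; compound 2 carries a different aryl group on the urea and a different substituent on the aminopyrimidine, so the two compounds are not a single-change pair and no step is tabulated between them.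

Compound 3, `CNc1nccc(N2CC[C@H](NC(=O)Nc3cccc(OC)c3)C2)n1`, is still to be measured in this assay. Relative to compound 1 the change is methoxy in place of cyano on an aromatic carbon of the urea-linked phenyl ring. There is no measured step of this kind in the series on which to anchor the direction. With one acceptor exchanged for one acceptor and no change in size or ring count, the expected step from compound 1 to compound 3 is a 1.1-fold higher number from compound 1 to compound 3 (0.06 log units; within the scatter), that is, none beyond the scatter, with a wide band of uncertainty. Compound 3 is therefore estimated at 4000 nM, in a range from 1000 nM to 16000 nM.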

Compound 3, half-maximal inhibitory concentration: 3620 nM
Compound 3: the middle estimate sits 1.1-fold (0.04 log units) above what was measured; the range from low to high includes it.
By their numbers in this assay, from the lowest: compound 2; then compounds 1 and 3 (each within the scatter of the next).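

In this assay, the series now has its first pair differing in one place: going from 3-cyanophenyl to 3-methoxyphenyl gives a 1.0-fold higher number from compound 1 to compound 3 (0.02 log units; within the scatter) and so leaves the reading within the scatter. On this aromatic carbon, meta to a large group, the nitrile and the methoxy group therefore cannot be told apart on this shared core, at least with the methylamino-substituted pyrimidine present in both compounds. Nothing available here bears on why the two groups read alike.

From the compounds shown here alone, it remains open whether this flat result holds for groups of another kind at the same carbon, such as a carboxylic acid, a dimethylamino group or a longer alkoxy chain, or for a phenyl ring with no substituent there. Compound 1 and compound 3 differ from compound 2 in more than one place, so the value of compound 2 (20.3 nM) cannot be divided between its aryl group and its cyclopropylamino group, and the separate contribution of each remains unresolved.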